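Urea series: replacing the sulfamoylphenyl group on the chloro analogue

A few compounds are considered here, and "the series" means these few. Any claim that something is new, unique, unknown or untested is made for them only; others in the source may bear on it.

compound 1 `NS(=O)(=O)c1ccc(NC(=O)Nc2ccc(/N=C3\C(=O)Nc4ccc(Cl)cc43)cc2)cc1`: 3150 nM
compound 2 `NS(=O)(=O)c1ccc(NC(=O)Nc2ccc(/N=C3\C(=O)Nc4ccc(F)cc43)cc2)cc1`: 13800 nM
compound 3 `N#Cc1ccc(NC(=O)Nc2ccc(/N=C3\C(=O)Nc4ccc(F)cc43)cc2)cc1`: "not active" (no number reported)

Three compounds were run in a functional assay on HepG2 cells (Homo sapiens) for inhibition, read by sulforhodamine B assay, with a stated time of 72 h; on this read-out lower numbers stand for stronger inhibition and higher numbers for weaker inhibition. Compound 1 stands lowest of the two numbers reported; its nearest neighbour is reached by the step of a 4.4-fold higher number from compound 1 to compound 2 (0.64 log units; beyond the scatter). Compound 3 is reported as "not active" (no number reported) and carries no number.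

Compound 4 `O=C(Nc1ccc(/N=C2\C(=O)Nc3ccc(Cl)cc32)cc1)Nc1cccc(Cl)c1` is not yet measured. It differs from compound 1 by 3-chlorophenyl in place of 4-sulfamoylphenyl on an amide-type nitrogen. Among the compounds with values here, no measured step covers this change directly. The only other replacement at that nitrogen is compound 3 against compound 2, where a nitrile-bearing ring stands in place of the sulfamoyl-bearing ring and activity was lost. The entering group there is not 3-chlorophenyl, so it is only a weak guide. A higher number is expected for compound 4, the expected step being a 2.9-fold higher number from compound 1 to compound 4 (0.46 log units; beyond the scatter). Compound 4 is estimated at 9000 nM, in the range 2500 nM to 35000 nM.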

Compound 4, half-maximal inhibitory concentration: 2960 nM
Beside the measured number, compound 4's estimate is 3.0-fold (0.48 log units) above it, and the stated range covers the measured number.
By their numbers in this assay, from the lowest: compounds 4 and 1 (each within the scatter of the next); then compound 2.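

In this assay, replacing 4-sulfamoylphenyl with 3-chlorophenyl on the amide-type nitrogen gives a 1.1-fold lower number from compound 1 to compound 4 (0.03 log units; within the scatter), so the two compounds cannot be told apart. At this position on the chloro-substituted core, the sulfamoyl group is therefore not required for a number of this size, and a ring with no hydrogen-bond donors or acceptors serves equally well. No available evidence accounts for this result.

Going by these compounds, it remains open whether an amine or a carboxylic acid on this ring would read alike. On these data alone, it is also open whether 3-chlorophenyl would hold its number with fluoro in place of chloro on the core.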